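Swapping the Fluoropyridine for a Chloroanilide

The source may hold more compounds than are shown below. What is called first, only, known or untested is meant among the compounds shown, and "the series" means these compounds.

Of the compounds shown here, three sharing one core have been tested in a functional assay on SK-BR-3 cells (Homo sapiens) for inhibition, read by MTT assay, with a stated time of 2 days, tested at 10 uM; on this read-out lower numbers stand for less inhibition of growth and higher numbers for more inhibition of growth at the one concentration tested. Compound 1 `CNC(=O)c1cc(Oc2ccc3nc(NC(=O)Nc4ccc(Cl)cc4Cl)sc3c2)ccn1` gives 22.3%, compound 2 `CNC(=O)c1cc(Oc2ccc3nc(NC(=O)Nc4cc(C(F)(F)F)cc(C(F)(F)F)c4)sc3c2)ccn1` gives 88.1%, and compound 3 `CNC(=O)c1cc(Oc2ccc3nc(NC(=O)c4cccc(F)n4)sc3c2)ccn1` gives 12.5%, the lowest of the three numbers, although its gap to compound 1 lies within the scatter and only compound 2 stands clearly apart. Compound 4 `CNC(=O)c1cc(Oc2ccc3nc(NC(=O)Nc4ccc(Cl)cc4)sc3c2)ccn1` is not yet measured. It differs from compound 3 in one place: (4-chlorophenyl)amino in place of 6-fluoropyridin-2-yl on a carbonyl carbon. Going by the values given here, the one measured step that bears on this change runs the other way, a number 9.8 percentage points lower from compound 1 to compound 3 (within the scatter), and compound 4 resembles compound 1 closely. A small step is therefore expected, estimated as a number 9.5 percentage points higher from compound 3 to compound 4 (within the scatter). Compound 4 is expected to give 22%, with a range from 8% to 40%.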

Compound 4, percent growth inhibition at one concentration: 50.8%
Compound 4: middle estimate off by 28.8 percentage points, on the low side; the whole stated range lies below it.
By their numbers in this assay, from the lowest: compounds 3 and 1 (each within the scatter of the next); then compound 4; then compound 2.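

In this assay, the swap of 6-fluoropyridin-2-yl for (4-chlorophenyl)amino on a carbonyl carbon is a large one (a number 38.3 percentage points higher from compound 3 to compound 4 (beyond the scatter)), whereas the related step between compound 1 and compound 3 stayed within the scatter. The chlorines on the phenyl ring therefore matter too: hydrogen in place of chloro on an aromatic carbon also moves the number (a number 28.5 percentage points higher from compound 1 to compound 4 (beyond the scatter)). Nothing given here explains either step. Still open, on these data alone, is how a morpholine or a plain cyclohexylamino group on the same carbonyl carbon would compare with (4-chlorophenyl)amino.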